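The source may hold more compounds than are shown below. What is called first, only, known or untested is meant among the compounds shown, and "the series" means these compounds.

Four compounds share one core and differ only at two outer positions. Compound 1 `Cc1ccccc1-c1nnc(NNC2CCCC2)s1` carries methyl on an aromatic carbon and cyclopentyl on an amine nitrogen. Compound 2 `Cc1ccccc1-c1nnc(NNc2ccccc2)s1` differs from compound 1 by phenyl in place of cyclopentyl on an amine nitrogen. Compound 3 `Clc1ccccc1-c1nnc(NNC2CCCC2)s1` differs from compound 1 by chloro in place of methyl on an aromatic carbon, and this is the whole difference between the two cores. Among the compounds with values here, compound 4 `Clc1ccccc1-c1nnc(NNc2ccccc2)s1` has not yet been tested; it differs from compound 3 by phenyl in place of cyclopentyl on an amine nitrogen, the same change as the one from compound 1 to compound 2, made at a place described in exactly the same words.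

In a functional assay on the whole organism with Mus musculus as the target, in the maximal electroshock model, with a stated time of 1 h (on this read-out higher numbers stand for an effect only at larger amounts of compound and lower numbers for an effect already at smaller amounts), compound 1 gives > 100 mg/kg, which is a limit of the assay rather than a number. Compound 2 likewise gives only a limit, > 100 mg/kg. Compound 3 also gives only a limit, > 100 mg/kg. The step that the two limits leave unreadable from compound 1 to compound 2 and the step that the two limits leave unreadable from compound 1 to compound 3 both remain unreadable because the limit of > 100 mg/kg in this assay, at which 3 of the 3 values shown sit, hides whatever movement there may be.

For compound 4 the step that the limit leaves unreadable from compound 3 to compound 4 is expected to be small, resting on the fact that the same change from compound 1 to compound 2 produced a step that the two limits leave unreadable from compound 1 to compound 2. Compound 4 is therefore expected to give about 150 mg/kg, most probably again reported only as a limit, with a plausible range from 60 mg/kg to 400 mg/kg.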

Compound 4, dose for half-maximal effect: > 100 mg/kg
Compound 4 ended at the assay's limit; the forecaster's own chance of this, stated with the estimate: 80%; the middle value is on the limit's open side.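

Compound 4, like compounds 1 to 3, gives only a limit in this assay, so neither the change from compound 3 to compound 4 nor the change from compound 2 to compound 4 can be read, because every result rests on the same limit: the limit of > 100 mg/kg in this assay, at which 4 of the 4 values shown sit. The compounds shown leave open whether phenyl in place of cyclopentyl, or chloro in place of methyl, alters the dose needed for an effect.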